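Methoxy for hydrogen on the phenyl of compound 1

A few compounds are considered here, and "the series" means these few. Any claim that something is new, unique, unknown or untested is made for them only; others in the source may bear on it.

Among the measured compounds shown here, compound 1 `CC(=O)N1N=C(c2ccc(OCc3cn(Cc4ccc([N+](=O)[O-])cc4)nn3)cc2)CC1c1ccccc1` and compound 2 `COc1cc(C2CC(c3ccc(OCc4cn(Cc5ccc([N+](=O)[O-])cc5)nn4)cc3)=NN2C(C)=O)ccc1Oc1cn(Cc2ccc([N+](=O)[O-])cc2)nn1` are the two measured members. In a functional assay on THP-1 cells (Homo sapiens) for inhibition, read by sulforhodamine B assay, tested at 100 uM (a higher number here means more inhibition of growth at the concentration tested, a lower number less inhibition of growth), compound 1 gives 22% and compound 2 gives 15%. Compound 1 carries the higher of the two numbers, but the gap to compound 2 lies within the scatter, so the two are not separated by this readout. Compound 3 `COc1ccc(C2CC(c3ccc(OCc4cn(Cc5ccc([N+](=O)[O-])cc5)nn4)cc3)=NN2C(C)=O)cc1` has not been measured in this assay. It differs from compound 1 in one place: methoxy in place of hydrogen on an aromatic carbon. For the measured compounds named here, no step between measured compounds bears on this change, so the expectation rests on compound 1, whose 22% is modest, and on the absence of any movement beyond the scatter across the two measured compounds. The step of a number 2 percentage points lower from compound 1 to compound 3 (within the scatter) is expected to be small, not clearly beyond the scatter in either direction. Compound 3 is therefore estimated at 20%, with a range from 5% to 38% in this assay.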

Compound 3, percent growth inhibition at one concentration: 26%
Compound 3: the middle estimate sits 6 percentage points below what was measured, within the range that was stated.
By their numbers in this assay, from the lowest: compounds 2, 1 and 3 (each within the scatter of the next, the first and the last beyond it).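

Phenyl to 4-methoxyphenyl provides the first one-place step in the series: in this assay, the change runs a number 4 percentage points higher from compound 1 to compound 3 (within the scatter). This position, para to a large group, therefore accepts methoxy in place of hydrogen without any movement beyond the scatter, so the readout does not separate the two compounds and gives no sign that this change matters for growth inhibition in these cells. No measurement available bears on the reason for the size of this step.

Open, from the compounds shown here alone, is whether a different group at this position, such as an amine, a carboxylic acid or a longer alkoxy chain, would produce a step beyond the scatter. With methoxy as the only replacement for hydrogen in a one-place comparison, the tolerance seen here cannot be extended to other groups.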